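The source may hold more compounds than are shown below. What is called first, only, known or untested is meant among the compounds shown, and "the series" means these compounds.

Compound 1 `COc1ccc2[nH]c3c(c2c1)CCNC31CCN(Cc2ccc([N+](=O)[O-])cc2F)CC1`: 5900 nM
Compound 2 `COc1ccc2[nH]c3c(c2c1)CCNC31CCN(Cc2ccc(Br)c(F)c2)CC1`: 1800 nM
Compound 3 `COc1ccc2[nH]c3c(c2c1)CCNC31CCN(Cc2ccc(Br)cc2F)CC1`: 1600 nM

In an assay on FRT cells for positive allosteric modulation of Cystic fibrosis transmembrane conductance regulator variant N1303K (Homo sapiens), in the presence of a further agent that is not named here (a lower number here means that less compound is needed, a higher number that more compound is needed for the effect), compound 3 gives the lowest of the three numbers, but compound 2 sits within the scatter of it, as a 1.1-fold lower number from compound 2 to compound 3 (0.05 log units; within the scatter) shows, so the two cannot be placed in order. The gap to compound 1 is real: a 3.7-fold lower number from compound 1 to compound 3 (0.57 log units; beyond the scatter), and likewise a 3.3-fold lower number from compound 1 to compound 2 (0.52 log units; beyond the scatter).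

Compound 4 `COc1ccc2[nH]c3c(c2c1)CCNC31CCN(Cc2ccc(F)c(Cl)c2F)CC1` differs from compound 3 in one place: 3-chloro-2,4-difluorophenyl in place of 4-bromo-2-fluorophenyl on a saturated chain carbon bound to an amine nitrogen in a ring. The measured steps bear on this only loosely. The swap of the fluorine position, a 1.1-fold lower number from compound 2 to compound 3 (0.05 log units; within the scatter), was without effect beyond the scatter, while the two modest steps from compound 1 replaced a nitro group, a change that compound 4 does not repeat. For the measured compounds named here, no measured step exchanges bromine for chlorine or adds a second fluorine. The step of a 1.4-fold higher number from compound 3 to compound 4 (0.14 log units; within the scatter) is therefore expected to stay within the scatter, leaning if anything toward a slightly higher number. Compound 4 is expected to give about 2200 nM in this assay, with a range from 900 nM to 5500 nM.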

Compound 4, half-maximal effective concentration: 4500 nM
Compound 4: the middle estimate sits 2.0-fold (0.31 log units) below what was measured; the range from low to high includes it.
By their numbers in this assay, from the lowest: compounds 3 and 2 (each within the scatter of the next); then compounds 4 and 1 (each within the scatter of the next).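

On the saturated chain carbon bound to an amine nitrogen in a ring, the halogen pattern of the phenyl group can matter beyond the scatter in this assay: the 3-chloro-2,4-difluorophenyl group gives a 2.8-fold higher number from compound 3 to compound 4 (0.45 log units; beyond the scatter), and a 2.5-fold higher number from compound 2 to compound 4 (0.40 log units; beyond the scatter). Its step from the nitro-bearing group, a 1.3-fold lower number from compound 1 to compound 4 (0.12 log units; within the scatter), stays within the scatter, so a phenyl group carrying only halogens can stand level with that group rather than with the two bromo-bearing ones. Nothing measured here explains this difference.

Because this change removes bromine, brings in chlorine and adds a second fluorine together, the compounds shown cannot assign the step to any one of these. As far as these compounds go, how a nitrile or a trifluoromethyl group in place of the bromine would behave also remains open.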